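Extending the oxan-4-yl group of compound 2

The compounds below may be only part of what the source reports. "The series", "measured", "known", "first", "only" and "open" are said of these compounds alone.

Measured in a functional assay on HT-29 cells (Homo sapiens) for inhibition, read by luminescence and CellTiter-Glo, with a stated time of 24 h; on this read-out lower numbers stand for an effect already at smaller amounts and higher numbers for an effect only at larger amounts of compound:
Compound 1 `CN1C(=S)[C@@H](NC(=O)c2nc(Cc3ccccc3)n(C3COC3)n2)COc2ccccc21`: 916 nM
Compound 2 `CN1C(=S)[C@@H](NC(=O)c2nc(Cc3ccccc3)n(C3CCOCC3)n2)COc2ccccc21`: 2260 nM

Compound 2 holds the higher of the two numbers, so it needs the larger amount to show its effect. Compound 3 `CN1C(=S)[C@@H](NC(=O)c2nc(Cc3ccccc3)n(CC3CCOCC3)n2)COc2ccccc21` keeps the shared core and alters one group: (oxan-4-yl)methyl in place of oxan-4-yl on an aromatic nitrogen. In words, this is (oxan-4-yl)methyl in place of oxan-4-yl on an aromatic nitrogen. For the measured compounds named here, only one measured step concerns this same place: a 2.5-fold higher number from compound 1 to compound 2 (0.39 log units; beyond the scatter). That step was modest and involved a different swap, so it suggests no clear direction for the new group. In this assay, a change beyond the scatter is therefore not firmly expected, though a similarly modest step remains possible. The expected step is a 1.3-fold lower number from compound 2 to compound 3 (0.10 log units; within the scatter). For compound 3, the estimated value is 1800 nM, with an expected range of 600 nM to 5500 nM.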

Compound 3, half-maximal effective concentration: 6310 nM
Compound 3: middle estimate off by 3.5-fold (0.54 log units), on the low side; measured number above the stated range.
By their numbers in this assay, from the lowest: compound 1; then compound 2; then compound 3.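

On this assay the swap of oxan-4-yl for (oxan-4-yl)methyl on the aromatic nitrogen gives a 2.8-fold higher number from compound 2 to compound 3 (0.45 log units; beyond the scatter) even though both groups hold the same six-membered non-aromatic ring and the same count of hydrogen-bond acceptors. This position therefore responds to extending the group and not only to exchanging one ring for another, and the full span from oxetan-3-yl to (oxan-4-yl)methyl is a 6.9-fold higher number from compound 1 to compound 3 (0.84 log units; beyond the scatter) in this series. Across these three compounds the number rises from compound 1 through compound 2 to compound 3, and none of them goes against that order.

No available evidence explains this rise. As far as these compounds go, whether an amine, a carboxylic acid or a longer chain on the same nitrogen would continue or reverse the order remains open.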